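The source may report more compounds than this note shows. Statements on the series, on what has been measured and on what is new or still open speak of the compounds shown alone.

Four compounds built on one shared core differ only in the group attached to the double-bonded nitrogen. Compound 1 `COc1ccc(/C(=N\O)c2ccc3c(ccn3C)c2)c(OC)c1OC` carries a hydroxy there, and in a functional assay on HeLa cells (Homo sapiens) for cytotoxicity, read by XTT assay, with a stated time of 72 h (a higher number here means a weaker inhibitor, a lower number a stronger inhibitor), compound 1 gives 76 nM. Compound 2 `COc1ccc(/C(=N\OC(C)=O)c2ccc3c(ccn3C)c2)c(OC)c1OC` is its acetoxy counterpart, and in this assay compound 2 gives 1000 nM, so that a 13-fold higher number from compound 1 to compound 2 (1.12 log units; beyond the scatter). Compound 3 `COc1ccc(/C(=N\N)c2ccc3c(ccn3C)c2)c(OC)c1OC` bears an amino group in that position; in this assay compound 3 gives 2000 nM, which places it at the highest of the three numbers, since a 26-fold higher number from compound 1 to compound 3 (1.42 log units; beyond the scatter) while a 2.0-fold higher number from compound 2 to compound 3 (0.30 log units; within the scatter). The unmeasured compound 4 `COc1ccc(/C(=N\NC(C)=O)c2ccc3c(ccn3C)c2)c(OC)c1OC` differs from compound 3 in one place: acetyl in place of hydrogen on an amine nitrogen. The measured step that bears most directly on this change is the acetylation on oxygen, where a 13-fold higher number from compound 1 to compound 2 (1.12 log units; beyond the scatter) was a large rise; the change from compound 2 to compound 3, by contrast, showed nothing beyond the scatter. By analogy, capping the amine with acetyl is expected to raise the number again, though because compound 3 already stands at 2000 nM a smaller step than in the oxygen case is expected: a 2.5-fold higher number from compound 3 to compound 4 (0.40 log units; beyond the scatter). Compound 4 is therefore estimated at 5000 nM in this assay, with a range from 1500 nM to 16000 nM.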

Compound 4, half-maximal inhibitory concentration: 1000 nM
Compound 4: middle estimate off by 5.0-fold (0.70 log units), on the high side; measured number below the stated range.
By their numbers in this assay, from the lowest: compound 1; then compounds 2, 4 and 3 (each within the scatter of the next).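

In this assay, acetyl on the amine nitrogen gives a 2.0-fold lower number from compound 3 to compound 4 (0.30 log units; within the scatter) and so does not repeat the large rise seen when acetyl was placed on the oxygen, where the data showed a 13-fold higher number from compound 1 to compound 2 (1.12 log units; beyond the scatter); at this position, the same acetyl change therefore does not carry a large step on every parent. The two acetylated groups also cannot be told apart, with no change at the digits printed from compound 2 to compound 4 (within the scatter), and the acetamido compound shares the large gap from the hydroxy parent, at a 13-fold higher number from compound 1 to compound 4 (1.12 log units; beyond the scatter), so that among the four groups only hydroxy stands clear of the others, while compounds 2, 3 and 4 form one group within the scatter of each other. No evidence is available that accounts for these numbers.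

The compounds shown leave open whether the low number of compound 1 depends on the free hydroxy itself or would survive with a methoxy group on the double-bonded nitrogen. They also leave open whether a methylamino or dimethylamino group there, or a longer acyl chain such as propanoyl in place of acetyl, would stay with compounds 2, 3 and 4.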